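The compounds below may be only part of what the source reports. "The series", "measured", "known", "first", "only" and "open" are said of these compounds alone.

Measured compounds:
Compound 1, `O=c1[nH]c(SCc2cccs2)nc2ccccc12`, in an ADME assay on MRC5 cells (Homo sapiens) for cytotoxicity, read by neutral red uptake (on this read-out higher numbers stand for lower toxicity in this test and lower numbers for higher toxicity in this test), gives > 64000 nM, which is a limit of the assay.
Compound 2, `O=c1[nH]c(SCc2ccccc2[N+](=O)[O-])nc2ccccc12`, in this assay gives > 64000 nM, again a limit.
Compound 3, `O=c1[nH]c(SCc2ccc([N+](=O)[O-])s2)nc2ccccc12`, in this assay gives > 64000 nM, again a limit.

All three measured values sit at the limit of > 64000 nM in this assay, at which 3 of the 3 values shown sit. The step from compound 1 to compound 3 is a step that the two limits leave unreadable from compound 1 to compound 3; the change behind it is nitro in place of hydrogen on an aromatic carbon. Compound 4, `O=c1[nH]c(SCc2c([N+](=O)[O-])cccc2[N+](=O)[O-])nc2ccccc12`, is not yet measured; it differs from compound 2 by nitro in place of hydrogen on an aromatic carbon. Going by the values given here, this is the same kind of change as the one from compound 1 to compound 3, but not the same: in compound 3 the nitro enters on a five-membered aromatic ring with one sulfur, next to the ring sulfur, two ring bonds from the ring atom that bears a large group, whereas in compound 4 it enters on a six-membered aromatic ring of carbon only, ortho to a large group and meta to a nitro group. How the core of compound 2 differs from the core of compound 1 is not broken down here. Among the compounds with values here, because compound 2 sits at the limit of > 64000 nM in this assay, at which 3 of the 3 values shown sit, and the one measured step of this kind is unreadable, the step from compound 2 to compound 4 is expected to be a step that the limit leaves unreadable from compound 2 to compound 4, most likely ending again at a limit. Compound 4 is therefore estimated at 100000 nM, within a range from 40000 nM to 300000 nM.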

Compound 4, half-maximal cytotoxic concentration: > 64000 nM
Compound 4: a limit, no number (the forecaster's own chance of this, stated with the estimate: 80%); the middle value is on the limit's open side.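

No step can be read between compound 2 and compound 4, or between compound 1 and compound 3, because all four compounds end at a limit rather than a number in this assay: the limit of > 64000 nM in this assay, at which 4 of the 4 values shown sit.

The compounds shown leave open at what concentration any of the four turns toxic in this assay, and so whether adding a nitro group changes that concentration at all.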